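Oxazolidinone amides: iodo to carboxy on the aryl ring

The compounds below may be only part of what the source reports. "The series", "measured", "known", "first", "only" and "open" are said of these compounds alone.

Measured compounds:
Compound 1 `Nc1cccc(CCCCCC(=O)N2CCOC2=O)c1`, in an assay on HEK293 cells for inhibition of N-acylethanolamine-hydrolyzing acid amidase (Rattus norvegicus), read by LC-MS, with a stated time of 30 min (a higher number here means a weaker inhibitor, a lower number a stronger inhibitor), compound 1 gives only a limit, > 20000 nM.
Compound 2 `O=C(CCCCCc1ccc(I)cc1)N1CCOC1=O`, in this assay compound 2 gives only a limit, > 20000 nM.

Both values shown so far sit at the limit of this assay, as the limit of > 20000 nM in this assay, at which 2 of the 2 values shown sit, records. Compound 2 therefore has no number of its own; it stands at the same limit as compound 1, and nothing separates the two within what is shown.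

The next compound in the series is compound 3 `O=C(O)c1ccc(CCCCCC(=O)N2CCOC2=O)cc1`. It differs from compound 2 in one place: carboxy in place of iodo on an aromatic carbon, the new group sitting on an aromatic carbon of the six-membered carbon-only ring, para to a large group. For the measured compounds named here, no measured step connects any two compounds here, so the size of this change in this assay cannot be read from data; two limits give no direction at all.

Compound 3 is expected to remain at or near the limit, with an estimated step from compound 2 of a number no higher from compound 2 to compound 3 (the limit leaves the size open). The estimate for compound 3 is 20000 nM, within a range of 5000 nM to 60000 nM, and the most likely outcome is that this assay again reports only a limit.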

Compound 3, half-maximal inhibitory concentration: > 20000 nM
Compound 3: only a limit was reported; the forecaster's own chance of this, stated with the estimate: 75%; the middle value lies on the limit itself.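

In this assay compound 3 gives > 20000 nM, which is a limit and not a number. For the compounds shown here, compound 2 also stands at a limit, so no step from compound 2 to compound 3 can be read for carboxy in place of iodo. The compounds shown leave open how strongly any of them inhibits, with every value at one limit: the limit of > 20000 nM in this assay, at which 3 of the 3 values shown sit.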